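This account rests on a few compounds, and the source may have more. Where it says the series, first, only, none or still open, it means among the compounds named here.

Compound 1 `COc1ccc(C(=O)Nc2ncc(C(Oc3ccc4cc(Br)ccc4c3)c3ccc(Cl)cc3)s2)cc1` was tested in an ADME assay on HepG2 2.2.15 cells (Homo sapiens) for cytotoxicity; a higher number here means that more compound is tolerated, a lower number that less compound is tolerated. In this assay compound 1 gives > 50000 nM, which is a limit of the assay rather than a number. Compound 2 `O=S(=O)(Nc1ncc(C(Oc2ccc3cc(Br)ccc3c2)c2ccc(Cl)cc2)s1)c1cccc2nsnc12` was examined the same way, and in this assay compound 2 is recorded as "not toxic" (no number reported), with no single number behind it. Compound 1 thus stands at the limit of > 50000 nM in this assay, at which 1 of the 2 values shown sits, beside one further entry that carries no number, so nothing can be ordered among the measured compounds. Compound 3 `COc1ccc(C(=O)Nc2ncc(C(Oc3ccc4cc(Br)ccc4c3)c3ccc(C#N)cc3)s2)cc1` has not yet been measured in this assay. It differs from compound 1 by cyano in place of chloro on an aromatic carbon. For the measured compounds named here, with no step between measured compounds available, a step no larger than the scatter is expected, in either direction, and the assay is likely to return a limit again. The step from compound 1 to compound 3 is estimated as a number no higher from compound 1 to compound 3 (the limit leaves the size open). For compound 3 the estimate in this assay is 50000 nM, within 20000 nM to 100000 nM.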

Compound 3, half-maximal cytotoxic concentration: "not toxic" (no number reported)
Compound 3: no number reported; no gap can be computed for the estimate.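

Compound 3 carries no number in this assay, and no step can be read from compound 1 to compound 3. Compound 1 stands only at a limit: the limit of > 50000 nM in this assay, at which 1 of the 3 values shown sits. The compounds shown leave open whether cyano in place of chloro shifts the tolerated concentration at all.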